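Ring contraction at the amide carbonyl: compound 3

The source may report more compounds than this note shows. Statements on the series, on what has been measured and on what is new or still open speak of the compounds shown alone.

Compound 1 `O=C(Nc1cc(-c2ccccc2)nn1-c1ccccc1)c1ccccc1` and compound 2 `O=C(Nc1cc(-c2ccccc2)nn1-c1ccccc1)C1CCCCC1` share one core and differ only in the group on the carbonyl carbon. In an assay on HEK293 cells for displacement of a labelled ligand from metabotropic glutamate receptor 5 (Rattus norvegicus) (a higher number here means a weaker inhibitor, a lower number a stronger inhibitor), compound 1 gives 4180 nM, and compound 2 gives 10100 nM. Among the compounds with values here, compound 2 thus stands at the weaker end of the two numbers measured so far, the only step to it being a 2.4-fold higher number from compound 1 to compound 2 (0.38 log units; beyond the scatter). Compound 3 `O=C(Nc1cc(-c2ccccc2)nn1-c1ccccc1)C1CCCC1` carries the change (cyclopentyl in place of cyclohexyl on a carbonyl carbon). Within the data shown here, no measured step covers a change of this kind; the only step at the same position, from compound 1 to compound 2, swaps an aromatic ring for a saturated one and is of modest size. The step to compound 3 is expected to be small or none beyond the scatter, since compound 2 is already the nearest point at 10100 nM. For compound 3 the expected step from compound 2 is a 1.1-fold lower number from compound 2 to compound 3 (0.05 log units; within the scatter), giving an estimate of 9000 nM with a range from 3000 nM to 30000 nM.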

Compound 3, inhibition constant: 11600 nM
Beside the measured number, compound 3's estimate is 1.3-fold (0.11 log units) below it, within the range that was stated.
By their numbers in this assay, from the lowest: compound 1; then compounds 2 and 3 (each within the scatter of the next).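

In this assay, the change from cyclohexyl to cyclopentyl on a carbonyl carbon gives a 1.1-fold higher number from compound 2 to compound 3 (0.06 log units; within the scatter), so across these two compounds the size of the saturated carbon ring does not separate the numbers. The step of a 2.8-fold higher number from compound 1 to compound 3 (0.44 log units; beyond the scatter) is modest, like a 2.4-fold higher number from compound 1 to compound 2 (0.38 log units; beyond the scatter), so both saturated rings stand apart from the phenyl of compound 1, which keeps the lowest number of the three. No evidence at hand bears on this result.

The compounds shown leave open whether an open chain such as isobutyl on the carbonyl carbon would read like the saturated rings or like the phenyl. They also leave open how a phenyl carrying a methoxy group or a fluorine, or a saturated ring carrying an amine, would compare with compound 1.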